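The source may hold more compounds than are shown below. What is called first, only, known or untested is meant among the compounds shown, and "the series" means these compounds.

Compound 1 `O=C(Nc1cccc(-n2cc(-c3ccncc3)c(-c3cc(O)cc(Cl)c3)n2)c1)Nc1ccc(Cl)c(Cl)c1`: -14.8%
Compound 2 `COc1cc(Cl)cc(-c2nn(-c3cccc(NC(=O)c4cccc(C(F)(F)F)c4)c3)cc2-c2ccncc2)c1`: 42%
Compound 3 `O=C(Nc1cccc(-n2cc(-c3ccncc3)c(-c3cc(O)cc(Cl)c3)n2)c1)c1cc(C(F)(F)F)cc(C(F)(F)F)c1`: 39.6%

Of the compounds shown here, three have so far been tested in a functional assay on OVCAR-8 cells (Homo sapiens) for inhibition, read by sulforhodamine B assay, with a stated time of 48 h, tested at 10 uM; on this read-out higher numbers stand for a weaker effect at the one concentration tested and lower numbers for a stronger effect. They share one core and differ in two places: in the group sitting on the oxygen of one aromatic ring, and in the part attached to the amide. Compound 1 gives -14.8% in this assay, far away from the other two. Compound 3 gives 39.6% and stands among the higher numbers of the set; its gap to compound 1 is well beyond the scatter, while compound 2, at 42%, lies within the scatter of compound 3, so the two cannot be told apart.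

Compound 4 `COc1cc(Cl)cc(-c2nn(-c3cccc(NC(=O)c4cc(C(F)(F)F)cc(C(F)(F)F)c4)c3)cc2-c2ccncc2)c1` has not been measured. It differs from compound 3 in a single place: methyl in place of hydrogen on an oxygen on an aromatic ring. Going by the values given here, no measured pair differs by this change alone, so its effect cannot be read off directly. Compound 2 already carries the methoxy form and compound 3 the hydroxy form, and their numbers sit within the scatter of each other, though they also differ at the amide. The step of a number 0.4 percentage points higher from compound 3 to compound 4 (within the scatter) is therefore expected to be none beyond the scatter. Compound 4 is expected to give 40%, most likely between 20% and 60%.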

Compound 4, a percentage reported as activity, at one concentration (the size of the read-out at that concentration, not a potency): 55.4%
Beside the measured number, compound 4's estimate is 15.4 percentage points below it, and the stated range covers the measured number.
By their numbers in this assay, from the lowest: compound 1; then compounds 3 and 2 (each within the scatter of the next); then compound 4.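

In this assay, going by these compounds alone, methyl in place of hydrogen on the oxygen gives a number 15.8 percentage points higher from compound 3 to compound 4 (beyond the scatter) and so a weaker effect at the one concentration tested, which is the first clean reading of hydroxy to methoxy at this position. The earlier comparison of compound 2 with compound 3 could not show this, since those two differ in more than one place. With the methoxy held constant, trifluoromethyl in place of hydrogen on an aromatic carbon of the amide part gives a number 13.4 percentage points higher from compound 2 to compound 4 (beyond the scatter) and so also weakens the effect, while no information shown gives a reason for either step.

Going by these compounds, each of these changes rests on a single pair, so it remains open whether either step would be the same size on a different amide part or on the urea-type link of compound 1. Also open, on these data alone, is how the number would respond to an ethoxy or a longer chain on that oxygen, or to an amine or a fluorine in place of the hydroxy.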